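From chloro to trifluoromethyl: a solubility estimate for compound 3

The compounds below may be only part of what the source reports. "The series", "measured", "known", "first", "only" and "open" are said of these compounds alone.

- Compound 1 `OC(c1ccc(Cl)cc1)(c1cccnc1)c1ccccc1Cl`: 3.1 ug/mL
- Compound 2 `CC(C)Oc1ccc(C(O)(c2ccc(Cl)cc2)c2cccnc2)cc1`: 1.6 ug/mL

These two numbers come from a physicochemical assay for solubility, read by nephelometry, measured as kinetic solubility, at pH 6.5; a higher number here means a more soluble compound, a lower number a less soluble compound. Repeated measurements of this kind naturally scatter, and the values of compound 1 and compound 2 lie within that scatter of each other. On this evidence, the two compounds cannot be ranked, and compound 2 at 1.6 ug/mL simply stands level with compound 1.

The next compound to be tested is compound 3 `CC(C)Oc1ccc(C(O)(c2ccc(C(F)(F)F)cc2)c2cccnc2)cc1`. It keeps the structure of compound 2 except at one place, on an aromatic carbon of a six-membered aromatic ring of carbon only, para to a large group. There, trifluoromethyl takes the place of chloro: trifluoromethyl in place of chloro on an aromatic carbon.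

Among the measured compounds shown here, no measured pair shows this exchange, so the only guide is the value of compound 2 at 1.6 ug/mL in this assay. A change beyond the scatter is not expected, and the estimated step, a 1.1-fold lower number from compound 2 to compound 3 (0.06 log units; within the scatter), is small and points slightly downward. For compound 3 the expected value is 1.4 ug/mL, with an estimated range from 0.6 ug/mL to 3.2 ug/mL.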

Compound 3, solubility: 1.6 ug/mL
Estimate against measurement, compound 3: 1.1-fold (0.06 log units) below; low and high end bracket the measured number.
By their numbers in this assay, from the lowest: compounds 2, 3 and 1 (each within the scatter of the next).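

Among the compounds shown here, this is the first pair in the set that differs in one place. A single exchange can now be read directly. In this assay, putting trifluoromethyl in place of chloro on this aromatic carbon, para to a large group, gives no change at the digits printed from compound 2 to compound 3 (within the scatter). So at this position, with the rest of the structure held constant, 4 heavy atoms can stand where 1 heavy atom stood without a difference that can be told apart from the scatter, and no measurement shown here explains why the two groups read alike.

Going by these compounds, this conclusion rests on one pair and one position, so it remains open whether an amine or a carboxylic acid on the same carbon would give a step beyond the scatter. On these data alone, it also remains open whether the same exchange would read alike on the core of compound 1, which also carries chloro on an aromatic carbon.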